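Step from compound 2 to compound 3 in kinase inhibition

This account rests on a few compounds, and the source may have more. Where it says the series, first, only, none or still open, it means among the compounds named here.

Measured compounds:
compound 1, `C#Cc1ccc2ncn(-c3ccnc(N)n3)c2c1`, 251 nM;
compound 2, `C=Cc1ccnc(C#Cc2ccc3ncn(-c4ccnc(N)n4)c3c2)n1`, 1580 nM.

Both numbers come from an assay on Sf9 cells for inhibition of mitogen-activated protein kinase kinase kinase 14 variant S549D (Homo sapiens), with a stated time of 30 min, in the presence of a further agent that is not named here; a higher number here means a weaker inhibitor, a lower number a stronger inhibitor. Among the measured compounds shown here, of the two, compound 2 stands at the higher number; its nearest neighbour is compound 1, and the one step seen so far, a 6.3-fold higher number from compound 1 to compound 2 (0.80 log units; beyond the scatter), goes beyond the scatter. Compound 3, `C#Cc1ncc(C#Cc2ccc3ncn(-c4ccnc(N)n4)c3c2)cn1`, has not been measured. It differs from compound 2 by a group of 8 heavy atoms (6 carbon, 2 nitrogen; one six-membered aromatic ring with 2 hetero atoms) in place of a group of 8 heavy atoms (6 carbon, 2 nitrogen; one six-membered aromatic ring with 2 hetero atoms), on a triple-bonded carbon. The group that leaves and the group that enters match in what is counted, the one holding a double bond and the other a triple bond outside the aromatic ring. For the measured compounds named here, only one measured step bears on the change: the step from compound 1 to compound 2 placed a group of this kind on the triple-bonded carbon and raised the number modestly. Going by the values given here, no step swaps one such group for another, so there is no measured basis for a direction. The step of a 1.1-fold lower number from compound 2 to compound 3 (0.02 log units; within the scatter) is therefore expected to stay within the scatter. For compound 3 the estimate in this assay is 1500 nM, within 600 nM to 4000 nM.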

Compound 3, half-maximal inhibitory concentration: 79400 nM
The estimate for compound 3 lay 53-fold (1.72 log units) below the measured number; the measured number lies above the stated range.
By their numbers in this assay, from the lowest: compound 1; then compound 2; then compound 3.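

In this assay, the result shows that what matters on this triple-bonded carbon is not only whether a group is present but which group it is: the leaving and entering groups match in heavy atoms, ring type, hydrogen-bond donors and acceptors and charge, yet the swap gives a 50-fold higher number from compound 2 to compound 3 (1.70 log units; beyond the scatter). Both groups raise the number relative to the hydrogen atom, but by very different amounts, since a 6.3-fold higher number from compound 1 to compound 2 (0.80 log units; beyond the scatter) stands against a 320-fold higher number from compound 1 to compound 3 (2.50 log units; beyond the scatter), so the cost of substitution here is not fixed by what these counts describe. No measurement shown explains the gap between the two groups.

The compounds shown leave open how much of the step follows the triple bond in place of the double bond outside the aromatic ring and how much follows the different arrangement of atoms in the two groups. They also leave open whether a group of another kind on this carbon, such as an amine, a hydroxymethyl group or a plain phenyl ring, could match or go below compound 1 at 251 nM.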